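Trimethylphenyl in Place of Dichlorophenyl: What to Expect

A few compounds are considered here, and "the series" means these few. Any claim that something is new, unique, unknown or untested is made for them only; others in the source may bear on it.

Compound 3 `N#CC1=C(N)Oc2c(N)cc3nc4ccccc4nc3c2C12C(=O)N(Cc1cnnn1-c1ccc(Cl)cc1Cl)c1ccccc12` gives only a limit in a functional assay on HCT-116 cells (Homo sapiens) for antiproliferative activity, read by MTT assay, with a stated time of 48 h (a higher number here means a weaker inhibitor, a lower number a stronger inhibitor), namely > 50000 nM. Compound 1 `N#CC1=C(N)Oc2c(N)cc3nc4ccccc4nc3c2C12C(=O)N(Cc1cnnn1-c1ccc(Cl)cc1)c1ccccc12` also gives only a limit, > 50000 nM. Compound 2 `N#CC1=C(N)Oc2c(N)cc3nc4ccccc4nc3c2C12C(=O)N(Cc1cnnn1-c1cccc(Br)c1)c1ccccc12` gives 26100 nM. Here (the limit of > 50000 nM in this assay, at which 2 of the 3 values shown sit). The change from 4-chlorophenyl to 3-bromophenyl gave an at least 1.9-fold lower number from compound 1 to compound 2 (0.28 log units; that floor lies within the scatter), the change onward to 2,4-dichlorophenyl gave an at least 1.9-fold higher number from compound 2 to compound 3 (0.28 log units; that floor lies within the scatter), and a step that the two limits leave unreadable from compound 1 to compound 3. Compound 4 `Cc1cc(C)c(-n2nncc2CN2C(=O)C3(C(C#N)=C(N)Oc4c(N)cc5nc6ccccc6nc5c43)c3ccccc32)c(C)c1` carries 2,4,6-trimethylphenyl in place of 2,4-dichlorophenyl on an aromatic nitrogen. Within the data shown here, none of the measured aryl swaps produced a step readable beyond the scatter, and two of three values stopped at the limit. Compound 4 is expected to give 50000 nM, with a range from 20000 nM to 150000 nM, most probably again reported only as a limit. The expected step is a number no higher from compound 3 to compound 4 (the limit leaves the size open), within the scatter.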

Compound 4, half-maximal inhibitory concentration: > 50000 nM
Compound 4: only a limit was reported (the forecaster's own chance of this, stated with the estimate: 65%); the middle value sits exactly at the limit.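

Methyl groups alone on the aryl ring, with no halogen, also leave compound 4 at a limit. Among these compounds, the steps from compound 1 and from compound 3 to compound 4 cannot be read, and the one readable step is an at least 1.9-fold higher number from compound 2 to compound 4 (0.28 log units; that floor lies within the scatter). Among the compounds shown here, four aryl groups at this position have therefore produced no step readable beyond the scatter, and most results now sit at one limit: the limit of > 50000 nM in this assay, at which 3 of the 4 values shown sit.

Going by these compounds, whether an aryl group bearing an amine or a carboxylic acid, or a longer chain in its place, would give a measurable number stays open. On these data alone, how compound 1, compound 3 and compound 4 rank among themselves also stays open.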